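Chloropyridine Replaces Fluoropyridine on the Amine Nitrogen

The compounds below may be only part of what the source reports. "The series", "measured", "known", "first", "only" and "open" are said of these compounds alone.

Measured compounds:
compound 1 `Fc1ccc(NCc2ccc(CNc3ccc(F)cn3)cc2)nc1`: 68%
compound 2 `c1ccc(NCc2ccc(CNc3ncccn3)cc2)cc1`: 100%
compound 3 `Fc1ccc(NCc2ccc(CNc3ncccn3)cc2)nc1`: 78%

All three were tested in a functional assay on MDA-MB-231 cells for antagonist activity at C-X-C chemokine receptor type 4 (Homo sapiens), tested at 100 nM; on this read-out higher numbers stand for a stronger effect at the one concentration tested and lower numbers for a weaker effect. Compound 3 stands second highest of the three numbers. Its nearest neighbour is compound 1, and the step of a number 10 percentage points higher from compound 1 to compound 3 (within the scatter) lies within the scatter, so the two cannot be ordered. Its furthest neighbour is compound 2, and the step of a number 22 percentage points lower from compound 2 to compound 3 (beyond the scatter) is beyond the scatter, a modest loss.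

Compound 4 `Clc1cccc(NCc2ccc(CNc3ncccn3)cc2)n1` has not yet been measured. Compared with compound 3 the change is 6-chloropyridin-2-yl in place of 5-fluoropyridin-2-yl on an amine nitrogen. Both measured steps also replace the aryl group on that amine nitrogen: from compound 1 to compound 3 the change stayed within the scatter, while from compound 2 to compound 3 it produced a modest loss. Neither step involves a chlorine on that ring, so there is no direct guide for this exchange. On the one hand, a halogenated pyridine remains in place; on the other, its substitution pattern changes. The expected step of a number 4 percentage points lower from compound 3 to compound 4 (within the scatter) is therefore small and not beyond the scatter. Compound 4 is estimated at 74%, with a range from 55% to 92%.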

Compound 4, a percentage reported as inhibition, at one concentration (the size of the read-out at that concentration, not a potency): 100%
The estimate for compound 4 lay 26 percentage points below the measured number; the whole stated range lies below it.
By their numbers in this assay, from the lowest: compounds 1 and 3 (each within the scatter of the next); then compounds 2 and 4 (each within the scatter of the next).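

In this assay, the exchange of 5-fluoropyridin-2-yl for 6-chloropyridin-2-yl on the amine nitrogen gives a number 22 percentage points higher from compound 3 to compound 4 (beyond the scatter), even though the two groups match in heavy-atom count, ring type, hydrogen-bond donors and acceptors, and differ only in the halogen and where it sits on the ring. Set against phenyl at the same place, the 6-chloropyridin-2-yl group gives no change at the digits printed from compound 2 to compound 4 (within the scatter), so a halogenated pyridine here does not always cost activity at the one concentration tested, although compound 3 still shows such a loss against compound 2. Nothing in the data available explains why these two halogenated pyridines differ.

The compounds shown leave open whether the step follows the identity of the halogen or its place on the ring, as the two change together between compound 3 and compound 4. They also leave open how far this place tolerates other groups, such as a bromine or a methyl group in place of the chlorine of the 6-chloropyridin-2-yl group, and a single concentration cannot separate compound 2 from compound 4 in potency.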